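This account rests on a few compounds, and the source may have more. Where it says the series, first, only, none or still open, it means among the compounds named here.

Working notes on the series. Compound 1 `COc1cc(-c2cc(/C=C/C(=O)c3ccc(N)cc3)[nH]n2)cc(OC)c1OC` and compound 2 `COc1ccc(-c2cc(/C=C/C(=O)c3ccc(N)cc3)[nH]n2)cc1OC` are built on one core. In a functional assay on HCC 2998 cells (Homo sapiens) for inhibition, read by sulforhodamine B assay, with a stated time of 48 h (on this read-out higher numbers stand for lower toxicity in this test and lower numbers for higher toxicity in this test), compound 1 gives 6530 nM, and compound 2 gives 7240 nM. The change between them, (hydrogen in place of methoxy on an aromatic carbon), produced a 1.1-fold higher number from compound 1 to compound 2 (0.04 log units; within the scatter). Compound 3 `COc1cc(C(=O)/C=C/c2cc(-c3cc(OC)c(OC)c(OC)c3)n[nH]2)cc(OC)c1OC` is built differently; the difference between the core of compound 3 and the core of compound 1 is not broken down here. In this assay compound 3 gives 6310 nM, a value that sits within the scatter of the values of compound 1 and compound 2. Compound 4 `COc1ccc(-c2cc(/C=C/C(=O)c3cc(OC)c(OC)c(OC)c3)[nH]n2)cc1OC` has not yet been measured. Going by the values given here, it arises from compound 3 by hydrogen in place of methoxy on an aromatic carbon, which is the same change as the one from compound 1 to compound 2, at an identically described place. Because a 1.1-fold higher number from compound 1 to compound 2 (0.04 log units; within the scatter) stayed within the scatter, the expected step is a 1.1-fold higher number from compound 3 to compound 4 (0.05 log units; within the scatter). For compound 4 in this assay the estimate is 7000 nM, expected to fall between 3500 nM and 14000 nM, resting on that single earlier step. The measurement is awaited.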

Compound 4, concentration lethal to 50% of the cells: 6090 nM
Beside the measured number, compound 4's estimate is 1.1-fold (0.06 log units) above it; the range from low to high includes it.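

In this assay the replacement of methoxy by hydrogen gives a 1.0-fold lower number from compound 3 to compound 4 (0.02 log units; within the scatter), so on the core of compound 3, as on the core of compound 1, the step stays within the scatter. Set side by side, the two steps do not differ: the same change on two cores in this assay, a 1.1-fold higher number (0.04 log units; within the scatter) from compound 1 to compound 2 and a 1.0-fold lower number (0.02 log units; within the scatter) from compound 3 to compound 4, 1.1-fold (0.06 log units) apart, within the scatter of two such steps. This shows that the change carries across these two cores with no readable effect on either, but it rests on two pairs in this assay and does not show that the same would hold on other cores, at other places on the ring or in other cells, nor can steps this small reveal a slight dependence on the core.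

The compounds shown carry only methoxy or hydrogen at this place, so what a hydroxyl group, a chlorine atom or an amine would do there stays open. Also open, going by these compounds, is whether any group there could move the number beyond the scatter on either core.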